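Chloro to Nitro: Estimating a New Analogue

This account rests on a few compounds, and the source may have more. Where it says the series, first, only, none or still open, it means among the compounds named here.

Of the compounds shown here, three built on one shared core have been tested in a functional assay on B16-F10 cells (Mus musculus) for inhibition, read by MTT assay, with a stated time of 72 h; a lower number here means a stronger inhibitor, a higher number a weaker inhibitor. Compound 1 `N#Cc1c(Nc2ccccc2Cl)nc(SCc2cn(Cc3ccccc3Cl)nn2)nc1-c1ccccc1` carries a 2-chlorophenyl on a nitrogen of the core and gives 8350 nM. Compound 2 `N#Cc1c(Nc2ccc(Cl)cc2)nc(SCc2cn(Cc3ccccc3Cl)nn2)nc1-c1ccccc1` carries a 4-chlorophenyl in that place and gives 1590 nM, while compound 3 `N#Cc1c(Nc2cccc(Cl)c2)nc(SCc2cn(Cc3ccccc3Cl)nn2)nc1-c1ccccc1` carries a 3-chlorophenyl and gives 3590 nM. Moving the chlorine around that ring produces modest shifts: a 5.3-fold lower number from compound 1 to compound 2 (0.72 log units; beyond the scatter), a 2.3-fold lower number from compound 1 to compound 3 (0.37 log units; beyond the scatter) and a 2.3-fold higher number from compound 2 to compound 3 (0.35 log units; beyond the scatter). Compound 3 therefore sits second highest of the three numbers, between compound 2 and compound 1, with each gap beyond the scatter.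

Compound 4 `N#Cc1c(Nc2cccc([N+](=O)[O-])c2)nc(SCc2cn(Cc3ccccc3Cl)nn2)nc1-c1ccccc1` differs from compound 3 in one place: nitro in place of chloro on an aromatic carbon. Among the compounds with values here, none of the measured steps exchanges the chloro for another group; all three only shift the chloro to another position, so they give no direct guide to what a nitro does. They do show that the ring in question tolerates changes with only modest consequences in this assay. On that basis the expected step of a 1.0-fold lower number from compound 3 to compound 4 (0.01 log units; within the scatter) is small, with no strong lean in either direction, and compound 4 is estimated at 3500 nM, between 1200 nM and 10000 nM.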

Compound 4, half-maximal inhibitory concentration: 17200 nM
Beside the measured number, compound 4's estimate is 4.9-fold (0.69 log units) below it; measured number above the stated range.
By their numbers in this assay, from the lowest: compound 2; then compound 3; then compound 1; then compound 4.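

In this assay, within the data shown here, the earlier compounds showed only what happens when a chlorine moves around this ring, whereas compound 4 shows that the choice of group matters too, with a nitro in the same ring position giving a step beyond the scatter (a 4.8-fold higher number from compound 3 to compound 4 (0.68 log units; beyond the scatter)). Compound 4 now has the highest number of the four, so it is the weakest inhibitor shown, and the nitro compound ends up weaker than even the 2-chlorophenyl compound (a 2.1-fold higher number from compound 1 to compound 4 (0.31 log units; beyond the scatter)), while the gap to the best of the chlorine compounds is the only large step in this set (an 11-fold higher number from compound 2 to compound 4 (1.03 log units; beyond the scatter)). Nothing available here explains why the nitro compound differs from the chlorine compounds.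

With only one nitro compound shown, it remains open whether a nitro would lose as much at the other ring positions, where moving the chlorine changed the number. From the compounds shown here alone, it is also open how a group of a different kind, such as an amine, a methoxy or a carboxylic acid, would behave in the place of the chloro.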